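The compounds below may be only part of what the source reports. "The series", "measured", "known", "first", "only" and "open" are said of these compounds alone.

Measured in a functional assay on BT-474 cells (Homo sapiens) for inhibition, read by fluorescence, with a stated time of 72 h; a lower number here means a stronger inhibitor of growth, a higher number a weaker inhibitor of growth:
- compound 1 `CC(C)CCn1cnc2c(NCc3cccc(Cl)c3)nc(N[C@H]3CC[C@H](N)CC3)nc21`: 6600 nM
- compound 2 `COc1cc(Nc2nc(N[C@H]3CC[C@H](N)CC3)nc3c2ncn3CCC(C)C)cc(OC)c1`: 5900 nM
- compound 3 `CC(C)CCn1cnc2c(Nc3cccc(Cl)c3)nc(N[C@H]3CC[C@H](N)CC3)nc21`: 3800 nM

Compound 3 gives 3800 nM, a number that cannot be separated from those of the other two compounds, since all three lie within the scatter of one another. The next compound, compound 4 `CC(C)CCn1cnc2c(Nc3ccc(O)cc3)nc(N[C@H]3CC[C@H](N)CC3)nc21`, carries 4-hydroxyphenyl in place of 3-chlorophenyl on a nitrogen on an aromatic ring.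

Three measured steps change the group at this same place: a 1.1-fold lower number from compound 1 to compound 2 (0.05 log units; within the scatter), a 1.7-fold lower number from compound 1 to compound 3 (0.24 log units; within the scatter) and a 1.6-fold lower number from compound 2 to compound 3 (0.19 log units; within the scatter). For the measured compounds named here, none goes beyond the scatter, so these compounds offer no precedent for a large step here. However, no measured compound carries the 4-hydroxyphenyl group, so the range must stay wide.

The expected change is a 1.1-fold higher number from compound 3 to compound 4 (0.02 log units; within the scatter), which means no step beyond the scatter is expected in this assay. For compound 4 the estimated value is 4000 nM, with an expected range from 1200 nM to 13000 nM.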

Compound 4, concentration for 50% growth inhibition: 7700 nM
Beside the measured number, compound 4's estimate is 1.9-fold (0.28 log units) below it; measured number inside the range.
By their numbers in this assay, from the lowest: compounds 3, 2, 1 and 4 (each within the scatter of the next, the first and the last beyond it).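

For the compounds shown here, replacing 3-chlorophenyl with 4-hydroxyphenyl on this nitrogen gives the only step that passes the scatter in this assay (a 2.0-fold higher number from compound 3 to compound 4 (0.31 log units; beyond the scatter)), and that step is modest. The comparisons with the other two compounds stay within the scatter (a 1.3-fold higher number from compound 2 to compound 4 (0.12 log units; within the scatter); a 1.2-fold higher number from compound 1 to compound 4 (0.07 log units; within the scatter)), so 4-hydroxyphenyl, which brings a hydrogen-bond donor and acceptor, is separated only from 3-chlorophenyl. Nothing available explains this step.

This change swaps the chlorine for a hydroxyl and also alters the substituent's ring position, so the compounds shown cannot separate these two differences. Comparing 3-hydroxyphenyl and 4-chlorophenyl on the same nitrogen could do so, while 4-aminophenyl would show whether another group gives a similar number.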